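The source may hold more compounds than are shown below. What is called first, only, known or untested is meant among the compounds shown, and "the series" means these compounds.

Compound 1 `COc1nc(N)nc2c1c(-c1cc3ccccc3o1)cn2[C@@H]1O[C@H](CO)[C@@H](O)[C@H]1O` gives > 20000 nM in a functional assay on HeLa S3 cells (Homo sapiens) for antiproliferative activity, read by XTT assay, with a stated time of 72 h (on this read-out lower numbers stand for stronger inhibition and higher numbers for weaker inhibition), a limit of the assay rather than a number.
Compound 2 `COc1ncnc2c1c(I)cn2[C@@H]1O[C@H](CO)[C@@H](O)[C@H]1O` gives 14300 nM in this assay.
Compound 3 `Cc1ncnc2c1c(-c1cc3ccccc3o1)cn2[C@@H]1O[C@H](CO)[C@@H](O)[C@H]1O` gives > 20000 nM in this assay, again a limit and not a number.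

Compound 3 therefore stands at the limit of > 20000 nM in this assay, at which 2 of the 3 values shown sit, with no measured number of its own. Compound 4 `COc1ncnc2c1c(-c1cc3ccccc3o1)cn2[C@@H]1O[C@H](CO)[C@@H](O)[C@H]1O` differs from it by methoxy in place of methyl on an aromatic carbon. Compound 1, which also carries the methoxy, rests at that same limit, while compound 2, likewise with the methoxy, is the only one of the three with a number. For the measured compounds named here, no pair of measured compounds differs in just one place, so no measured step gives a scale for this change. The step from compound 3 to compound 4 is expected to bring no shift beyond the usual scatter, an at least 1.1-fold lower number from compound 3 to compound 4 (0.04 log units; that floor lies within the scatter). Compound 4 is expected at 18000 nM, within 5000 nM to 60000 nM, and most likely reported only as a limit once more.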

Compound 4, half-maximal inhibitory concentration: 9240 nM
For compound 4 the middle estimate is 1.9-fold (0.29 log units) above the measured one; measured number inside the range.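

With compound 4, this position gains its first measured step: in this assay, methoxy in place of methyl on an aromatic carbon gives an at least 2.1-fold lower number from compound 3 to compound 4 (0.33 log units; beyond the scatter). Hydrogen in place of amino on an aromatic carbon gives an at least 2.1-fold lower number from compound 1 to compound 4 (0.33 log units; beyond the scatter), while 1-benzofuran-2-yl in place of iodo gives a 1.5-fold lower number from compound 2 to compound 4 (0.19 log units; within the scatter). The steps from compound 3 and compound 1 start from limits of the assay, so they are bounds only: the limit of > 20000 nM in this assay, at which 2 of the 4 values shown sit.

On these data alone, the true size of those two steps stays open. So does what an ethoxy group or an amine would do in place of the methoxy.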